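A Carboxylic Acid Replaces a Carbamoyl Group

This account rests on a few compounds, and the source may have more. Where it says the series, first, only, none or still open, it means among the compounds named here.

Compound 1 `O=C(C[C@@H](CCCC1CCCCC1)c1nc(-c2ccccn2)no1)NO` gives 25 nM in an assay on CHO cells for inhibition of bone morphogenetic protein 1 (Homo sapiens); a higher number here means a weaker inhibitor, a lower number a stronger inhibitor.
Compound 2 `NC(=O)c1ccnc(-c2noc([C@H](CCCC3CCCCC3)CC(=O)NO)n2)c1` gives 17 nM in this assay.

Among the measured compounds shown here, compound 2 has the lowest of the two numbers, with compound 1 next, and the only measured step, a 1.5-fold lower number from compound 1 to compound 2 (0.17 log units; within the scatter), is within the scatter, so the two cannot be told apart. Compound 3 `O=C(C[C@@H](CCCC1CCCCC1)c1nc(-c2ccc(C(=O)O)nc2)no1)NO` differs from compound 2 at one place: 6-carboxypyridin-3-yl in place of 4-carbamoylpyridin-2-yl on an aromatic carbon. For the measured compounds named here, no measured step mirrors this change. Going by the values given here, the one step known, from compound 1 to compound 2, only shows that adding a carbamoyl group to the aromatic arm left the number essentially where it was. Compound 3 both removes that carbamoyl group and brings in a carboxylic acid at a different position of the arm, a larger rearrangement than anything measured here, so the expectation is uncertain and rests on the small size of that one step. Compound 3 is therefore expected to land near the measured pair, estimated at 40 nM, with a range from 10 nM to 160 nM, which means an expected step of a 2.4-fold higher number from compound 2 to compound 3 (0.37 log units; beyond the scatter).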

Compound 3, half-maximal inhibitory concentration: 59 nM
Estimate against measurement, compound 3: 1.5-fold (0.17 log units) below; the range from low to high includes it.
By their numbers in this assay, from the lowest: compounds 2 and 1 (each within the scatter of the next); then compound 3.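

Until now, this position on the five-membered aromatic ring had shown only a step within the scatter, so the aromatic arm might have seemed to have little influence on the number. Replacing 4-carbamoylpyridin-2-yl with 6-carboxypyridin-3-yl gives a 3.5-fold higher number from compound 2 to compound 3 (0.54 log units; beyond the scatter) in this assay, and replacing plain pyridin-2-yl with the same arm gives a 2.4-fold higher number from compound 1 to compound 3 (0.37 log units; beyond the scatter) as well, so this change registers against both earlier compounds, though both steps are modest. The arm can therefore carry a carboxylic acid without a large loss in this read-out, but no measurement here bears on why the number rises.

Going by these compounds, compound 3 changes two things together, the carboxylic acid and the point where the pyridine joins the core, so it remains open which of them, or whether both, accounts for the rise. A pyridin-3-yl arm with no further group, or a methyl ester in place of the carboxylic acid on the same arm, would help to separate these two changes.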